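Removing one methoxy group across two related cores

The source may hold more compounds than are shown below. What is called first, only, known or untested is meant among the compounds shown, and "the series" means these compounds.

In a functional assay on OVCAR-3 cells (Homo sapiens) for cytotoxicity, read by sulforhodamine B assay, with a stated time of 48 h, tested at 10 uM (a lower number here means a stronger effect, a higher number a weaker effect of the compound at the concentration tested), compound 1 `COc1cc(-c2cc(/C=C/C(=O)c3ccc(N)cc3)[nH]n2)cc(OC)c1OC` gives -71%. Compound 2 `COc1ccc(-c2cc(/C=C/C(=O)c3ccc(N)cc3)[nH]n2)cc1OC` gives -56% in this assay. The change between them, (hydrogen in place of methoxy on an aromatic carbon), carries a step of a number 15 percentage points higher from compound 1 to compound 2 (beyond the scatter). Compound 3 `COc1cc(C(=O)/C=C/c2cc(-c3cc(OC)c(OC)c(OC)c3)n[nH]2)cc(OC)c1OC` gives -96% in this assay, the lowest number of the three measured. The difference between the core of compound 1 and the core of compound 3 is not broken down here. Compound 4 `COc1ccc(-c2cc(/C=C/C(=O)c3cc(OC)c(OC)c(OC)c3)[nH]n2)cc1OC` is not yet measured; it arises from compound 3 by hydrogen in place of methoxy on an aromatic carbon, the same change as in the measured pair, at a place described in the same words. Because the measured pair shows a number 15 percentage points higher from compound 1 to compound 2 (beyond the scatter), a step of about the same size, a number 15 percentage points higher from compound 3 to compound 4 (beyond the scatter), is expected, resting on this single precedent only. Compound 4 is thus estimated at -81%, between -95% and -62%.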

Compound 4, a percentage reported as activity, at one concentration (the size of the read-out at that concentration, not a potency): -85%
The estimate for compound 4 lay 4 percentage points above the measured number, and the stated range covers the measured number.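

In this assay, hydrogen in place of methoxy on an aromatic carbon gives a number 11 percentage points higher from compound 3 to compound 4 (beyond the scatter), so the change carries from one core to the other in the same direction and with a step of similar size: the same change on two cores in this assay, a number 15 percentage points higher (beyond the scatter) from compound 1 to compound 2 and a number 11 percentage points higher (beyond the scatter) from compound 3 to compound 4, 4 percentage points apart, within the scatter of two such steps. This supports using the step as a working estimate for these two cores. For the compounds shown here, it rests on only two pairs, however, and does not show that the step would hold on other cores or at any other methoxy group.

The compounds shown leave open what a hydroxy group, an amine or a longer ethoxy chain would do in place of this methoxy group. Also open, going by these compounds, is whether the step repeats when a further methoxy group gives way to hydrogen.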